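This account rests on a few compounds, and the source may have more. Where it says the series, first, only, none or still open, it means among the compounds named here.

Within the data shown here, in a functional assay on SH-SY5Y cells (Homo sapiens) for cytotoxicity, read by MTT assay, with a stated time of 72 h (a higher number here means a weaker inhibitor, a lower number a stronger inhibitor), three compounds have numbers so far. Compound 1 `CC[S+]([O-])CCCCN=C=S` stands at 9810 nM and compound 2 `CC(C)[S+]([O-])CCCCN=C=S` at 9420 nM while compound 3 `CC(C)C[S+]([O-])CCCCN=C=S` reads 5700 nM on the same scale. Compound 2 therefore sits in a tight group, with no real separation from either of the other two. The measured steps show this: they are a 1.0-fold lower number from compound 1 to compound 2 (0.02 log units; within the scatter) and a 1.7-fold lower number from compound 2 to compound 3 (0.22 log units; within the scatter) together with a 1.7-fold lower number from compound 1 to compound 3 (0.24 log units; within the scatter) and none of them reaches beyond the usual scatter of repeat measurements.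

Compound 4 `CC(C)[S+]([O-])CCCN=C=S` differs from compound 2 in one place (a group of 3 heavy atoms (1 carbon, 1 nitrogen, 1 sulfur; no ring) in place of a group of 4 heavy atoms (2 carbon, 1 nitrogen, 1 sulfur; no ring), on a saturated chain carbon, three bonds along the chain from a sulfur). Among the measured compounds shown here, none of the three measured steps makes a change of this kind, so they bear on it only indirectly, and the data hold no direct precedent. For the measured compounds named here, they show only that these three compounds do not separate when the groups at the sulfur end differ. Starting from compound 2 at 9420 nM and with so little to go on, no step beyond the scatter is expected in this assay here, though a surprise in either direction remains possible. The estimated step is a 1.1-fold higher number from compound 2 to compound 4 (0.03 log units; within the scatter) and no more than that. Compound 4 is estimated at 10000 nM with an expected range from 5000 nM to 20000 nM for the coming measurement.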

Compound 4, half-maximal inhibitory concentration: 18100 nM
Estimate against measurement, compound 4: 1.8-fold (0.26 log units) below, within the range that was stated.
By their numbers in this assay, from the lowest: compounds 3, 2, 1 and 4 (each within the scatter of the next, the first and the last beyond it).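

In this assay, among these compounds, this is the first change away from the sulfur end of the molecule: on a saturated chain carbon, three bonds along the chain from a sulfur, the group of 3 heavy atoms replaces the group of 4 heavy atoms, giving a 1.9-fold higher number from compound 2 to compound 4 (0.28 log units; within the scatter). Among the compounds shown here, this pair therefore offers the first direct reading at this position, and the two compounds do not separate, so exchanging these two groups has no effect here that can be told apart from ordinary repeat-to-repeat variation. Nothing available explains the size of this step or shows what lies behind it.

A single pair cannot show whether a longer chain at this place, or an amine or a carboxylic acid in place of the group, would move the number beyond the scatter. It also leaves open whether the same exchange would read alike with isobutyl rather than isopropyl on the sulfur, so the result cannot yet be taken as a rule for the whole series.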